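Aryl swap on the saturated ring carbon: compound 4

The source may hold more compounds than are shown below. What is called first, only, known or untested is meant among the compounds shown, and "the series" means these compounds.

The series shares one core, seen in compound 1 `N#CC1=C(N)N(c2ccc(S(N)(=O)=O)cc2)C2=C(C(=O)CCC2)C1c1ccc(O)cc1`, compound 2 `COc1cc(CC2C(C#N)=C(N)N(c3ccc(S(N)(=O)=O)cc3)C3=C2C(=O)CCC3)ccc1O` and compound 3 `N#CC1=C(N)N(c2ccc(S(N)(=O)=O)cc2)C2=C(C(=O)CCC2)C1c1ccc([N+](=O)[O-])cc1`, and varies in the group carried on a saturated ring carbon. In a functional assay on Ehrlich cells (Mus musculus) for antiproliferative activity, read by trypan blue exclusion, with a stated time of 2 h, tested at 25 ug/mL (on this read-out lower numbers stand for a weaker effect and higher numbers for a stronger effect at the one concentration tested), compound 1 gives 95%. In this assay compound 2 gives 50%. In this assay compound 3 gives 80%, the second highest of the three numbers: a number 15 percentage points lower from compound 1 to compound 3 (beyond the scatter), while a number 30 percentage points higher from compound 2 to compound 3 (beyond the scatter).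

Compound 4 `COc1ccc2ccccc2c1C1C(C#N)=C(N)N(c2ccc(S(N)(=O)=O)cc2)C2=C1C(=O)CCC2` is the next member. 2-methoxynaphthalen-1-yl in place of 4-nitrophenyl on a saturated ring carbon

Two measured steps alter the same saturated ring carbon: a number 45 percentage points lower from compound 1 to compound 2 (beyond the scatter), and a number 30 percentage points higher from compound 2 to compound 3 (beyond the scatter). The third, a number 15 percentage points lower from compound 1 to compound 3 (beyond the scatter), changes only a substituent on the aromatic ring. Changes at the saturated ring carbon have therefore moved the number by modest to large amounts in both directions, and no measured compound carries two fused aromatic rings there, so the direction for compound 4 is uncertain. The expectation for compound 4 is a modest decrease, a number 15 percentage points lower from compound 3 to compound 4 (beyond the scatter), with a wide margin.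

Compound 4 is estimated at 65% in this assay, within a range from 35% to 90%.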

Compound 4, a percentage reported as activity, at one concentration (the size of the read-out at that concentration, not a potency): 62%
Estimate against measurement, compound 4: 3 percentage points above; the measured number falls inside the stated range.
By their numbers in this assay, from the lowest: compound 2; then compound 4; then compound 3; then compound 1.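

In this assay, the saturated ring carbon accepts 2-methoxynaphthalen-1-yl, a group with two six-membered aromatic rings of carbon only, and the activity is reduced but not lost, with a number 18 percentage points lower from compound 3 to compound 4 (beyond the scatter) and a number 33 percentage points lower from compound 1 to compound 4 (beyond the scatter). The same group still reads better than 4-hydroxy-3-methoxybenzyl, with a number 12 percentage points higher from compound 2 to compound 4 (beyond the scatter), so among these four compounds the number does not simply fall as aromatic rings are added: compound 2, which carries one aromatic ring, stands lowest. No supporting measurement is available to explain why these groups rank as they do.

The compounds shown leave open how much of the step to compound 4 belongs to the methoxy group and how much to the second aromatic ring, a question that unsubstituted naphthalen-1-yl or 2-hydroxynaphthalen-1-yl at this carbon would address. They also leave open how a phenyl ring bearing an amine or a carboxylic acid at this carbon would compare with the hydroxy and nitro groups of compound 1 and compound 3.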